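One amide change to compound 1

This account rests on a few compounds, and the source may have more. Where it says the series, first, only, none or still open, it means among the compounds named here.

compound 1 `CCN(CC)S(=O)(=O)c1ccc(S(=O)(=O)N2CCC[C@@H](C(=O)N3CCC(O)CC3)C2)cc1`: 870 nM
compound 2 `CCC(CC)S(=O)(=O)c1ccc(S(=O)(=O)N2CCC[C@@H](C(=O)N3CCC(F)(F)CC3)C2)cc1`: 13 nM

In a functional assay on MIA PaCa-2 cells (Homo sapiens) for inhibition, read by MTT assay, with a stated time of 7 days (on this read-out lower numbers stand for stronger inhibition and higher numbers for weaker inhibition), compound 1 (870 nM) stands highest of the two numbers, and compound 2 (13 nM) lies beyond the scatter below it. Relative to compound 1, compound 3 `CCN(CC)S(=O)(=O)c1ccc(S(=O)(=O)N2CCC[C@@H](C(=O)NC3COC3)C2)cc1` carries (oxetan-3-yl)amino in place of 4-hydroxypiperidin-1-yl on a carbonyl carbon. Among the measured compounds shown here, no measured step isolates this change, so no step beyond the scatter is expected, in either direction. The estimated step is small: a 1.2-fold lower number from compound 1 to compound 3 (0.09 log units; within the scatter) is what is expected here. Compound 3 is expected at 700 nM in this assay (estimated range 180 nM to 2700 nM) with considerable uncertainty.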

Compound 3, half-maximal inhibitory concentration: 2340 nM
Estimate against measurement, compound 3: 3.3-fold (0.52 log units) below; low and high end bracket the measured number.
By their numbers in this assay, from the lowest: compound 2; then compound 1; then compound 3.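

In this assay, among the compounds shown here, (oxetan-3-yl)amino in place of 4-hydroxypiperidin-1-yl on a carbonyl carbon gives a 2.7-fold higher number from compound 1 to compound 3 (0.43 log units; beyond the scatter) and provides the first measured single-place step at this position. The step is modest but beyond the scatter, although both groups have the same counted hydrogen-bond donors and acceptors. Nothing given explains this step. Left open is whether cyclobutylamino on the same carbonyl carbon would read like (oxetan-3-yl)amino, and how 4,4-difluoropiperidin-1-yl would read on the core of compound 1.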